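The compounds below may be only part of what the source reports. "The series", "measured", "known", "first", "only" and "open" are said of these compounds alone.

Two hydroxamic acids built on the same core have been measured. Compound 1 `O=C(CCC1=CCN(CCCc2ccc(Br)cc2)C1=O)NO` carries a bromo group on its aromatic ring, and in a functional assay on ACHN cells (Homo sapiens) for inhibition, read by sulforhodamine B assay (on this read-out lower numbers stand for stronger inhibition of growth and higher numbers for weaker inhibition of growth), compound 1 gives 3330 nM. Compound 2 `Cc1cccc(CN2CC=C(CCC(=O)NO)C2=O)c1`, which carries a methyl-substituted benzyl group on the ring nitrogen instead of the three-carbon-linked aryl chain, gives in this assay 3330 nM. On the numbers shown, compound 1 stands level with compound 2 at the digits given; the two values lie within the scatter of each other, so nothing separates them.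

Compound 3 `CC(C)(C)c1ccc(CCCN2CC=C(CCC(=O)NO)C2=O)cc1` has not yet been measured in this assay. It differs from compound 1 in one place: tert-butyl in place of bromo on an aromatic carbon. Going by the values given here, no step between measured compounds bears on this exchange, so there is nothing to set a direction; the step from compound 1 to compound 3 is expected to be small, amounting to a 1.1-fold lower number from compound 1 to compound 3 (0.05 log units; within the scatter), no further than the scatter. For compound 3 in this assay a value of 3000 nM is estimated, within a range from 1000 nM to 9000 nM.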

Compound 3, concentration for 50% growth inhibition: 3330 nM
Beside the measured number, compound 3's estimate is 1.1-fold (0.05 log units) below it; the measured number falls inside the stated range.
By their numbers in this assay, from the lowest: compounds 1, 2 and 3 (each within the scatter of the next).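

Going by these compounds alone, the exchange of bromo for tert-butyl, on an aromatic carbon para to a large group, gives no change at the digits printed from compound 1 to compound 3 (within the scatter) in this assay, and this is the first reading of any change at this position. The entering group has 4 heavy atoms against 1 for the group that leaves, so in this pair a larger all-carbon group takes the place of bromo without a difference in the number that can be told from the scatter. Nothing measured here bears on why the two compounds read alike.

The compounds shown leave open whether an amine or a carboxylic acid on this aromatic carbon would read differently from bromo and tert-butyl. They also leave open whether a longer chain on the ring nitrogen would move the number with the aromatic group held fixed.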